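The source may report more compounds than this note shows. Statements on the series, on what has been measured and on what is new or still open speak of the compounds shown alone.

Measured so far in a functional assay on MIA PaCa-2 cells (Homo sapiens) for inhibition, read by MTT assay, with a stated time of 7 days; on this read-out higher numbers stand for weaker inhibition and lower numbers for stronger inhibition:
compound 1 `CCN(CC)S(=O)(=O)c1ccc(S(=O)(=O)N2CCC[C@@H](C(=O)N3CCC(O)CC3)C2)cc1` gives 870 nM
compound 2 `CC(C)CS(=O)(=O)c1ccc(S(=O)(=O)N2CCC[C@@H](C(=O)N3CCC(F)(F)CC3)C2)cc1` gives 80 nM
compound 3 `CCN(CC)S(=O)(=O)c1ccc(S(=O)(=O)N2CCC[C@@H](C(=O)N[C@H]3CC[C@@H](OC)CC3)C2)cc1` gives 960 nM

Compound 3 holds the highest of the three numbers in this assay. Its nearest neighbour is compound 1, which differs from it only in the group on the carbonyl carbon, and the step of a 1.1-fold higher number from compound 1 to compound 3 (0.04 log units; within the scatter) shows that this exchange stayed within the scatter. For the measured compounds named here, compound 2 lies far lower at 80 nM, but it differs from compound 3 in two places and offers no single step to lean on.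

Compound 4 `CCN(CC)S(=O)(=O)c1ccc(S(=O)(=O)N2CCC[C@@H](C(=O)N[C@H]3CCOC3)C2)cc1` remains to be measured. It differs from compound 3 in one place: oxolan-3-yl in place of 4-methoxycyclohexyl on an amide-type nitrogen. Going by the values given here, the only measured step that touches the amide substituent is a 1.1-fold higher number from compound 1 to compound 3 (0.04 log units; within the scatter), and it stayed within the scatter. Nothing measured separates a five-membered non-aromatic ring with one hetero atom from a methoxy-bearing six-membered ring at this position. Compound 4 is therefore expected to show a 1.3-fold higher number from compound 3 to compound 4 (0.10 log units; within the scatter), a step no larger than the scatter. For compound 4 the estimate in this assay is 1200 nM, with a range from 400 nM to 4000 nM.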

Compound 4, half-maximal inhibitory concentration: 1670 nM
Compound 4: the middle estimate sits 1.4-fold (0.14 log units) below what was measured; low and high end bracket the measured number.
By their numbers in this assay, from the lowest: compound 2; then compounds 1, 3 and 4 (each within the scatter of the next).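

In this assay the exchange of 4-methoxycyclohexyl for oxolan-3-yl on the amide-type nitrogen gave a 1.7-fold higher number from compound 3 to compound 4 (0.24 log units; within the scatter) and so stayed within the scatter, even though the entering group has a five-membered ring with one hetero atom and fewer heavy atoms. The exchange of 4-hydroxypiperidin-1-yl for (oxolan-3-yl)amino on the carbonyl carbon gave a 1.9-fold higher number from compound 1 to compound 4 (0.28 log units; within the scatter) and also stayed within the scatter, so the three groups on this carbonyl carbon are not told apart by these numbers. No evidence is available that accounts for this result.

As far as these compounds go, whether an amine or a carboxylic acid on the ring, or an open alkyl chain in place of the ring, would move the number beyond the scatter remains open. Also open, from the compounds shown here alone, is how much of the value of compound 2 at 80 nM belongs to each of the places in which it differs from the other compounds.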